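Swapping cyclopropylmethyl for sec-butyl on an aromatic carbon

The source may report more compounds than this note shows. Statements on the series, on what has been measured and on what is new or still open speak of the compounds shown alone.

Compound 1 `N#Cc1ccc(Nc2ncc(Cc3c(F)cc(F)cc3F)o2)cc1Cl` and compound 2 `N#Cc1ccc(Nc2ncc(Cc3c(F)cc(CC4CC4)cc3F)o2)cc1Cl` were tested in an ADME assay on MT2 cells (Homo sapiens) for inhibition; on this read-out higher numbers stand for lower toxicity in this test and lower numbers for higher toxicity in this test. Compound 1 gives 7000 nM, and compound 2 gives 29000 nM, the higher of the two numbers. Among the measured compounds shown here, the single measured step, a 4.1-fold higher number from compound 1 to compound 2 (0.62 log units; beyond the scatter), puts cyclopropylmethyl in place of fluoro on an aromatic carbon. Compound 3 `CCC(C)c1cc(F)c(Cc2cnc(Nc3ccc(C#N)c(Cl)c3)o2)c(F)c1` differs from compound 2 by sec-butyl in place of cyclopropylmethyl on an aromatic carbon. For the measured compounds named here, no measured step exchanges one such group for another of like size, so that step gives only loose guidance, and a change no larger than the usual scatter is expected, a 1.2-fold lower number from compound 2 to compound 3 (0.06 log units; within the scatter). In this assay compound 3 is therefore expected to give 25000 nM, within a range from 10000 nM to 60000 nM.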

Compound 3, half-maximal cytotoxic concentration: 40000 nM
Beside the measured number, compound 3's estimate is 1.6-fold (0.20 log units) below it; the range from low to high includes it.
By their numbers in this assay, from the lowest: compound 1; then compounds 2 and 3 (each within the scatter of the next).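

With sec-butyl in place of cyclopropylmethyl, which removes the three-membered ring but keeps the same number of carbons, this assay shows a 1.4-fold higher number from compound 2 to compound 3 (0.14 log units; within the scatter), so it does not separate these two groups. Sec-butyl in place of fluoro gives a 5.7-fold higher number from compound 1 to compound 3 (0.76 log units; beyond the scatter), so a second four-carbon group at this position stands clear of fluoro, as cyclopropylmethyl did. Nothing available explains these results. On these data alone, whether any group of this kind would do the same stays open, and an amine or a longer chain at this position would test that.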